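A few compounds are considered here, and "the series" means these few. Any claim that something is new, unique, unknown or untested is made for them only; others in the source may bear on it.

Four close relatives of one shared core were compared for how strongly they curb the growth of cultured cells. Compound 1 `O=C(/C=C/c1ccc(OCCCCCO[N+](=O)[O-])c(O)c1)OCCCCCO[N+](=O)[O-]` carries a hydroxy on its aromatic ring. In a functional assay on LOX IMVI cells (Homo sapiens) for cytotoxicity, read by resazurin assay, with a stated time of 72 h (on this read-out lower numbers stand for stronger inhibition and higher numbers for weaker inhibition), compound 1 gives 7230 nM. Compound 3 `COc1cc(/C=C/C(=O)OCCCCCO[N+](=O)[O-])ccc1OCCCCCO[N+](=O)[O-]` differs from compound 1 by methyl in place of hydrogen on an oxygen on an aromatic ring. For compound 3 this assay reports only a limit, > 50000 nM. The change thus made a step of an at least 6.9-fold higher number from compound 1 to compound 3 (0.83 log units; beyond the scatter). Compound 2 `O=C(/C=C/c1ccc(OCCCCCCO[N+](=O)[O-])c(O)c1)OCCCCCCO[N+](=O)[O-]` keeps the hydroxy of compound 1, but the difference between the two cores is not broken down here. For compound 2 this assay likewise reports only a limit, > 50000 nM. Compound 4 `COc1cc(/C=C/C(=O)OCCCCCCO[N+](=O)[O-])ccc1OCCCCCCO[N+](=O)[O-]`, not yet measured, differs from compound 2 by methyl in place of hydrogen on an oxygen on an aromatic ring, the same change as from compound 1 to compound 3, at the same place. Since compound 2 already stands at the limit of > 50000 nM in this assay, at which 2 of the 3 values shown sit, and the same change weakened compound 1 when it became compound 3, compound 4 is expected to stay at or beyond that limit, an expected step that the limit leaves unreadable from compound 2 to compound 4. The estimate for compound 4 is 100000 nM, between 50000 nM and 300000 nM.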

Compound 4, half-maximal inhibitory concentration: > 50000 nM
Compound 4 was reported as a limit; the forecaster's own chance of this, stated with the estimate: 90%; the middle value is on the limit's open side.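

In this assay compound 4 gives only a limit, > 50000 nM. Going by these compounds alone, compound 2 is also reported only as a limit, so no step between compound 2 and compound 4 can be read. Both stand at the same mark: the limit of > 50000 nM in this assay, at which 3 of the 4 values shown sit. The compounds shown leave open how far past that limit compound 2, compound 3 and compound 4 lie, and whether hydroxy to methoxy changes anything on the core of compound 2.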